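The source may report more compounds than this note shows. Statements on the series, on what has been measured and on what is new or still open speak of the compounds shown alone.

Compound 1 `C[C@H]1CC[C@@H]2[C@@H](OC(=O)[C@]23CC(c2ccccc2Br)=NO3)[C@]2(C)C(=O)C=C[C@@]12O` gives 44000 nM in a functional assay on SW-620 cells (Homo sapiens) for cytotoxicity, read by sulforhodamine B assay, with a stated time of 48 h; a higher number here means a weaker inhibitor, a lower number a stronger inhibitor. Among the three measured compounds its number is the second highest: compound 2 `C[C@H]1CC[C@@H]2[C@@H](OC(=O)[C@]23CC(c2ccc(O)cc2)=NO3)[C@]2(C)C(=O)C=C[C@@]12O` gives 89000 nM in this assay, and compound 3 `C[C@H]1CC[C@@H]2[C@@H](OC(=O)[C@]23CC(c2ccc(F)cc2)=NO3)[C@]2(C)C(=O)C=C[C@@]12O` gives 3600 nM. The two changes made at the same carbon pull in opposite directions: a 2.0-fold higher number from compound 1 to compound 2 (0.31 log units; beyond the scatter), whereas a 12-fold lower number from compound 1 to compound 3 (1.09 log units; beyond the scatter). Between those two, a 25-fold lower number from compound 2 to compound 3 (1.39 log units; beyond the scatter).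

Compound 4 `C[C@H]1CC[C@@H]2[C@@H](OC(=O)[C@]23CC(c2ccc(C#N)cc2)=NO3)[C@]2(C)C(=O)C=C[C@@]12O` differs from compound 1 in one place: 4-cyanophenyl in place of 2-bromophenyl on a carbon with a double bond to nitrogen. Both earlier steps bear on this one, since each also replaced 2-bromophenyl with another ring carrying a single group. The 4-fluorophenyl ring brought a large drop in the number, the 4-hydroxyphenyl ring a modest rise, so the 4-cyanophenyl ring could land anywhere between, and the data give no closer guide. A lower number than compound 1 is therefore expected, though smaller than the step to compound 3, and with wide uncertainty. Compound 4 is estimated at 12000 nM, between 3000 nM and 48000 nM, which would mean an expected 3.7-fold lower number from compound 1 to compound 4 (0.56 log units; beyond the scatter).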

Compound 4, half-maximal inhibitory concentration: 53000 nM
For compound 4 the middle estimate is 4.4-fold (0.65 log units) below the measured one; the whole stated range lies below it.
By their numbers in this assay, from the lowest: compound 3; then compounds 1, 4 and 2 (each within the scatter of the next, the first and the last beyond it).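

In this assay, the 4-cyanophenyl ring does not reproduce the gain seen with 4-fluorophenyl on this carbon of the five-membered ring: a 15-fold higher number from compound 3 to compound 4 (1.17 log units; beyond the scatter). Compound 4 instead sits with the 2-bromophenyl and 4-hydroxyphenyl compounds (a 1.2-fold higher number from compound 1 to compound 4 (0.08 log units; within the scatter); a 1.7-fold lower number from compound 2 to compound 4 (0.23 log units; within the scatter)), so compound 3 alone stands apart, and a single group on this ring does not by itself bring a lower number. Nothing shown here explains the gap between the fluoro and cyano rings.

From the compounds shown here alone, it remains open whether the low number of compound 3 is specific to fluoro, or would also appear with 4-chlorophenyl or an amine on the ring. The 2-bromophenyl ring also differs from the others in both group and ring position, so 4-bromophenyl would be needed to separate those two changes.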